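Trifluoromethyl in Place of Fluoro: Expecting Compound 3

This account rests on a few compounds, and the source may have more. Where it says the series, first, only, none or still open, it means among the compounds named here.

Of the compounds shown here, two that share one core have been measured in a functional assay on CHO-K1 cells for antagonist activity at prostaglandin E2 receptor EP1 subtype (Homo sapiens), read by FLIPR; on this read-out lower numbers stand for stronger inhibition and higher numbers for weaker inhibition. Compound 1 `Cc1cc(C(=O)O)nn1Cc1cc(Br)ccc1OCc1ccccc1` carries a hydrogen where compound 2 `Cc1cc(C(=O)O)nn1Cc1cc(Br)ccc1OCc1ccc(F)cc1` carries a fluoro. In this assay compound 1 gives 15.1 nM, and compound 2 gives 11.8 nM. Within the data shown here, the one recorded step between them is a 1.3-fold lower number from compound 1 to compound 2 (0.11 log units; within the scatter), so the two numbers sit within the scatter of each other, and compound 2 stands alongside compound 1 rather than apart from it.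

Compound 3 `Cc1cc(C(=O)O)nn1Cc1cc(Br)ccc1OCc1ccc(C(F)(F)F)cc1` has not been measured. It differs from compound 2 in one place: trifluoromethyl in place of fluoro on an aromatic carbon. Among the measured compounds shown here, the only measured step that bears on this spot is the exchange of hydrogen for fluoro from compound 1 to compound 2, and that step stayed within the scatter. A group with more atoms entering at the same spot has no measured precedent among these compounds, so the expectation rests on that single step alone. The number for compound 3 is therefore expected to move little, with a 1.0-fold higher number from compound 2 to compound 3 (0.01 log units; within the scatter) as the estimated step. Compound 3 is estimated to give 12 nM, with a range from 5 nM to 35 nM.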

Compound 3, inhibition constant: 97.7 nM
Estimate against measurement, compound 3: 8.1-fold (0.91 log units) below; the whole stated range lies below it.
By their numbers in this assay, from the lowest: compounds 2 and 1 (each within the scatter of the next); then compound 3.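

The spot on the ring that carries fluoro in compound 2 is not indifferent to what sits there: in this assay trifluoromethyl in place of fluoro gives an 8.3-fold higher number from compound 2 to compound 3 (0.92 log units; beyond the scatter) and thus weaker inhibition, although hydrogen and fluoro had stayed within the scatter of each other. The comparison with hydrogen points the same way, with a 6.5-fold higher number from compound 1 to compound 3 (0.81 log units; beyond the scatter) as the step, so the weakening appears against both smaller neighbours in the series and does not depend on which of them serves as the reference. No measurement at hand explains why trifluoromethyl behaves so differently from fluoro at this position.

The compounds shown cover only hydrogen, fluoro and trifluoromethyl at this spot, so it stays open whether a methyl group, a chlorine atom or a methoxy group would stand with the first two or with trifluoromethyl. As far as these compounds go, it is also open whether the same exchange would weaken inhibition to a similar extent if the bromo group on the shared core were replaced by a chloro group or a methyl group.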